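This account rests on a few compounds, and the source may have more. Where it says the series, first, only, none or still open, it means among the compounds named here.

Measured compounds:
Compound 1, `Cc1[nH]cnc1/C=c1\[nH]c(=O)/c(=C/c2cccc(Oc3ccc(F)cc3)c2)[nH]c1=O`, gives 47.6 nM in a functional assay on NCI-H460 cells (Homo sapiens) for cytotoxicity, read by MTT assay, with a stated time of 72 h; a higher number here means a weaker inhibitor, a lower number a stronger inhibitor.
Compound 2, `O=c1[nH]/c(=C\c2ccccn2)c(=O)[nH]/c1=C\c1cccc(Oc2ccc(F)cc2)c1`, gives 49.1 nM in this assay.
Compound 3, `O=c1[nH]/c(=C\c2ncc[nH]2)c(=O)[nH]/c1=C\c1cccc(Oc2ccc(F)cc2)c1`, reaches only the limit of > 1000 nM in this assay.

Compound 1 holds the lowest of the two numbers given, yet the step of a 1.0-fold higher number from compound 1 to compound 2 (0.01 log units; within the scatter) lies within the scatter, so compounds 1 and 2 cannot be ranked against each other. For compound 3 only a limit is known (the limit of > 1000 nM in this assay, at which 1 of the 3 values shown sits). Compound 4, `O=c1[nH]/c(=C\c2ccc([N+](=O)[O-])o2)c(=O)[nH]/c1=C\c1cccc(Oc2ccc(F)cc2)c1`, differs from compound 1 in one place: 5-nitrofuran-2-yl in place of 5-methyl-1H-imidazol-4-yl on a double-bonded chain carbon bound to an aromatic carbon. Going by the values given here, the steps that bear on this position are a 1.0-fold higher number from compound 1 to compound 2 (0.01 log units; within the scatter), an at least 21-fold higher number from compound 1 to compound 3 (1.32 log units; beyond the scatter) and an at least 20-fold higher number from compound 2 to compound 3 (1.30 log units; beyond the scatter): one swap of the ring cost nothing, the other two cost much. The ring entering in compound 4 matches none of those measured, so a modest upward step a 3.2-fold higher number from compound 1 to compound 4 (0.50 log units; beyond the scatter) is expected, with wide uncertainty. Compound 4 is estimated at 150 nM, between 40 nM and 1000 nM.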

Compound 4, half-maximal inhibitory concentration: > 1000 nM
Compound 4 was reported as a limit; the forecaster's own chance of this, stated with the estimate: 25%; middle value at least 6.6-fold (0.82 log units) away from the limit.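

The 5-nitrofuran-2-yl ring of compound 4 shows that a large loss at this position is not peculiar to the 1H-imidazol-2-yl ring of compound 3, with an at least 21-fold higher number from compound 1 to compound 4 (1.32 log units; beyond the scatter) and an at least 20-fold higher number from compound 2 to compound 4 (1.30 log units; beyond the scatter). A five-membered ring alone does not decide the outcome, as compound 1 also carries one and gives 47.6 nM. The step from compound 3 to compound 4 cannot be read, as both values are limits: the limit of > 1000 nM in this assay, at which 2 of the 4 values shown sit.

From the compounds shown here alone, how far compound 3 and compound 4 lie beyond that limit remains unknown. Going by these compounds, whether a plain phenyl ring, or a pyridin-2-yl ring bearing an amine, would keep the low number also remains open.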